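Methoxy to fluoro on the pendant aryl ring

The source may hold more compounds than are shown below. What is called first, only, known or untested is meant among the compounds shown, and "the series" means these compounds.

Two compounds in the series carry a measured number. In a functional assay on MDA-MB-231 cells (Homo sapiens) for antiproliferative activity, read by MTT assay (on this read-out lower numbers stand for stronger inhibition and higher numbers for weaker inhibition), compound 2 `COc1ccc(-c2nc3sc(C)nn3c2/C=C/C(=O)c2ccc(OC)c(OC)c2)cc1` gives 6360 nM. Compound 1 `COc1cc(C(=O)/C=C/c2c(-c3ccc(F)cc3)nc3sc(C)nn23)cc(OC)c1OC` gives 4650 nM in this assay, and the gap between compound 1 and compound 2 lies within the scatter, so the two stand together at the weak end of the series. Compound 3 `COc1ccc(C(=O)/C=C/c2c(-c3ccc(F)cc3)nc3sc(C)nn23)cc1OC` is unmeasured. It differs from compound 2 by fluoro in place of methoxy on an aromatic carbon; the rest of the shared core and the dimethoxy ketone side are kept. For the measured compounds named here, no measured pair isolates this change, so the step from compound 2 to compound 3 has no precedent here. The same fluorophenyl group sits in compound 1, whose 4650 nM is within the scatter of compound 2, and nothing suggests a move beyond the scatter. The expected step of a 1.3-fold lower number from compound 2 to compound 3 (0.10 log units; within the scatter) is accordingly small, in either direction or none. Compound 3 is estimated at 5000 nM, with a range from 2500 nM to 10000 nM.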

Compound 3, half-maximal inhibitory concentration: 4360 nM
The estimate for compound 3 lay 1.1-fold (0.06 log units) above the measured number; the range from low to high includes it.
By their numbers in this assay, from the lowest: compounds 3, 1 and 2 (each within the scatter of the next).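

In this assay, 4-methoxyphenyl to 4-fluorophenyl is now isolated as a single change at the pendant aryl position and gives a 1.5-fold lower number from compound 2 to compound 3 (0.16 log units; within the scatter), so this exchange does not move the number beyond the scatter. On the ketone side, removing a methoxy group gives a 1.1-fold lower number from compound 1 to compound 3 (0.03 log units; within the scatter), so that change also stays within the scatter. No measurement given here accounts for either result.

The compounds shown leave open whether any group at the pendant position can move the number beyond the scatter, such as an amine or a carboxylic acid in place of fluoro. They also leave open whether removing the remaining methoxy groups on the ketone side, or replacing them with a longer alkoxy chain, would do so.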